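From 3-Chlorophenyl to 2-Chlorophenyl on a Carbonyl Carbon

The source may report more compounds than this note shows. Statements on the series, on what has been measured and on what is new or still open speak of the compounds shown alone.

In an ADME assay on microsomes from liver (Homo sapiens) for metabolic stability, with a stated time of 10 min, tested at 0.5 uM (a lower number here means that less of the compound is left, a higher number that more of the compound is left), compound 1 `C[C@@H](NCc1ccc(Cl)cc1)[C@H]1CC[C@@H](c2ccnc3ccc(F)cc32)CC1` gives 34% and compound 2 `C[C@@H](NC(=O)c1cccc(Cl)c1)[C@H]1CC[C@@H](c2ccnc3ccc(F)cc32)CC1` gives 39% so the two sit within the scatter of each other. Among the compounds with values here, the only measured step is a number 5 percentage points higher from compound 1 to compound 2 (within the scatter) and it puts (3-chlorophenyl)carbonyl in place of 4-chlorobenzyl on an amine nitrogen. Compound 3 `C[C@@H](NC(=O)c1ccccc1Cl)[C@H]1CC[C@@H](c2ccnc3ccc(F)cc32)CC1` carries 2-chlorophenyl in place of 3-chlorophenyl on a carbonyl carbon and its difference from compound 2 reads 2-chlorophenyl in place of 3-chlorophenyl on a carbonyl carbon with the same atoms joined differently. Nothing measured tests this exchange directly. Within the data shown here, with compound 2 at 39% and the step of a number 5 percentage points higher from compound 1 to compound 2 (within the scatter) as the only guides, no change beyond the scatter is expected in this assay and in neither direction. The estimated step is a number 1 percentage points lower from compound 2 to compound 3 (within the scatter) and no more. Compound 3 is expected at 38% with an estimated range from 22% to 55% as its likely span.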

Compound 3, percent of the compound remaining: 21%
Compound 3: the middle estimate sits 17 percentage points above what was measured; measured number outside the range, below it.
By their numbers in this assay, from the lowest: compound 3; then compounds 1 and 2 (each within the scatter of the next).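

In this assay, the exchange of 3-chlorophenyl for 2-chlorophenyl on a carbonyl carbon gives a number 18 percentage points lower from compound 2 to compound 3 (beyond the scatter), so with the same atoms joined differently, the arrangement of this chlorophenyl group makes a difference beyond the scatter, something the earlier pair could not show. The step from the 4-chlorobenzyl group to (2-chlorophenyl)carbonyl on the amine nitrogen gives a number 13 percentage points lower from compound 1 to compound 3 (beyond the scatter), whereas (3-chlorophenyl)carbonyl stayed within the scatter of compound 1, so the outcome of that exchange depends on which chlorophenyl group the carbonyl carries. No measurement shown here accounts for the lower number of compound 3.

On these data alone, it remains open how (4-chlorophenyl)carbonyl or an unsubstituted benzoyl group would compare at this nitrogen. As far as these compounds go, it is equally open whether 2-fluorophenyl or 2-methoxyphenyl on the carbonyl carbon would follow compound 3 or compound 2.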